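Hydroxy Groups Placed on Two Lactone Scaffolds

The source may hold more compounds than are shown below. What is called first, only, known or untested is meant among the compounds shown, and "the series" means these compounds.

Compound 1 `O=C1OC[C@H](Cc2ccccc2)[C@H]1Cc1ccccc1` opens this small set. In a functional assay on HL-60 cells (Homo sapiens) for cytotoxicity, read by WST assay, with a stated time of 48 h (a lower number here means that less compound is needed, a higher number that more compound is needed for the effect), compound 1 gives 77000 nM. Compound 2 `O=C1OC[C@H](Cc2ccccc2)[C@H]1Cc1ccc(O)cc1` carries one group more, (hydroxy in place of hydrogen on an aromatic carbon), and in this assay compound 2 gives 88000 nM; the step of a 1.1-fold higher number from compound 1 to compound 2 (0.06 log units; within the scatter) is small. Compound 3 `COc1ccc(C[C@H]2COC(=O)[C@@H]2Cc2ccc(Cl)c(Cl)c2)cc1` rests on a different core; the difference between the cores of compound 1 and compound 3 is not broken down here. In this assay compound 3 gives 37000 nM, the lowest of the three numbers, with compound 1 as its nearest neighbour.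

Compound 4 `COc1ccc(C[C@H]2COC(=O)[C@@H]2Cc2ccc(Cl)c(Cl)c2)cc1O` is the one still to be measured. It differs from compound 3 by hydroxy in place of hydrogen on an aromatic carbon. This is the same kind of change as that from compound 1 to compound 2, though the place differs: in compound 2 the hydroxy stands para to a large group, whereas in compound 4 it stands ortho to a methoxy group and meta to a large group. Compound 4 is expected to show a step of similar size, a 1.1-fold higher number from compound 3 to compound 4 (0.03 log units; within the scatter), because the earlier step of a 1.1-fold higher number from compound 1 to compound 2 (0.06 log units; within the scatter) stayed within the scatter. Compound 4 is therefore estimated at 40000 nM in this assay, with a likely range from 18000 nM to 90000 nM.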

Compound 4, half-maximal effective concentration: 32000 nM
For compound 4 the middle estimate is 1.3-fold (0.10 log units) above the measured one; the range from low to high includes it.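

In this assay, hydroxy in place of hydrogen on an aromatic carbon gives a 1.2-fold lower number from compound 3 to compound 4 (0.06 log units; within the scatter) on the core of compound 3, a step that stays within the scatter. Set beside the earlier step, the change carries over between these two cores without a difference that can be told apart: the same change on two cores in this assay, a 1.1-fold higher number (0.06 log units; within the scatter) from compound 1 to compound 2 and a 1.2-fold lower number (0.06 log units; within the scatter) from compound 3 to compound 4, 1.3-fold (0.12 log units) apart, within the scatter of two such steps. Going by these compounds alone, this does not show that the change would be equally quiet on any other core or at any other place, since only two cores are compared, the hydroxy of compound 4 stands ortho to a methoxy group and meta to a large group, and its place on compound 2 differs.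

The compounds shown leave open whether another group at the place taken by hydroxy in compound 4, such as an amine, a carboxylic acid or a longer chain, would give a step beyond the scatter. They also leave open how the same change would read in any other assay.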